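The source may report more compounds than this note shows. Statements on the series, on what has been measured and on what is new or still open speak of the compounds shown alone.

Three compounds share a scaffold in which an imidazo-fused core carries a benzimidazole unit and a second aromatic group. Compound 1 `c1ccc2c(-c3cn4ccnc4c(-c4ccc5ncn(C6CCCCC6)c5c4)n3)cccc2c1` carries a cyclohexyl on the benzimidazole nitrogen and a naphthyl as the second group; in a functional assay on SK-MEL-5 cells (Homo sapiens) for inhibition, read by sulforhodamine B assay, with a stated time of 48 h, tested at 10 uM (on this read-out higher numbers stand for more inhibition at the one concentration tested (going by the name of the read-out) and lower numbers for less inhibition), compound 1 gives 4.06%. Compound 2 `c1ccc(Cn2cnc3ccc(-c4nc(-c5cccc6ccccc56)cn5ccnc45)cc32)cc1` keeps the naphthyl, and in this assay compound 2 gives 9.69%. The change from compound 1 to compound 2 is benzyl in place of cyclohexyl on an aromatic nitrogen, and the step it made was a number 5.6 percentage points higher from compound 1 to compound 2 (within the scatter).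

Compound 3 `c1cn2cc(-c3ccc4c(c3)ncn4C3CCCCC3)nc(-c3ccc4ncn(C5CCCCC5)c4c3)c2n1` replaces the naphthyl with a second cyclohexyl-bearing benzimidazole; the difference between its core and that of compound 1 is not broken down here. In this assay compound 3 gives 36.8%, the highest of the three numbers, beyond the scatter from both compound 2 and compound 1.

Compound 4 `c1ccc(Cn2cnc3ccc(-c4nc(-c5ccc6c(c5)ncn6C5CCCCC5)cn5ccnc45)cc32)cc1` has not yet been measured. It differs from compound 3 by benzyl in place of cyclohexyl on an aromatic nitrogen, the same change, at the same place, that was made from compound 1 to compound 2. Going by the values given here, since that earlier step was a number 5.6 percentage points higher from compound 1 to compound 2 (within the scatter), the account expects the step from compound 3 to compound 4 to be a number 3.2 percentage points higher from compound 3 to compound 4 (within the scatter), again within the scatter, because the one measured example of this change, a number 5.6 percentage points higher from compound 1 to compound 2 (within the scatter), gave no movement beyond it. On that basis compound 4 is estimated to give 40% in this assay, with a likely range from 24% to 56%.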

Compound 4, a percentage reported as inhibition, at one concentration (the size of the read-out at that concentration, not a potency): -84%
The estimate for compound 4 lay 124 percentage points above the measured number; measured number outside the range, below it.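

In this assay, benzyl in place of cyclohexyl on an aromatic nitrogen gave a number 120.8 percentage points lower from compound 3 to compound 4 (beyond the scatter), so the outcome seen on the core of compound 1 did not carry over to the core of compound 3: the same change on two cores in this assay, a number 5.6 percentage points higher (within the scatter) from compound 1 to compound 2 and a number 120.8 percentage points lower (beyond the scatter) from compound 3 to compound 4, 126.4 percentage points apart, beyond the scatter of two such steps In these two pairs, then, the result of the change depends on the core that carries it, and a step measured on one core is a poor guide to the step on the other. Going by these compounds alone, this does not show why the two cores part ways, and with only two pairs, measured in one assay at one concentration, it sets no rule for any other core.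

The compounds shown leave open whether a longer chain on the same nitrogen, such as phenylethyl, or a benzyl bearing an amine or a carboxylic acid on its ring, would behave like compound 2 or like compound 4. They also leave open what a compound with benzyl on both benzimidazole nitrogens would give, since compound 4 keeps one cyclohexyl, and whether a smaller group such as methyl on that nitrogen would follow either pair.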